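Dropping one chloro from the core of compound 2

A few compounds are considered here, and "the series" means these few. Any claim that something is new, unique, unknown or untested is made for them only; others in the source may bear on it.

Compound 2 `ClCc1ccccc1Cn1cnc2c(Cl)nc(Cl)nc21` gives 1020 nM in a functional assay on U-251 cells (Homo sapiens) for cytotoxicity, read by sulforhodamine B assay, with a stated time of 48 h (a lower number here means a stronger inhibitor of growth, a higher number a weaker inhibitor of growth), the lower of the two numbers available, while compound 1 `ClCc1ccc(Cn2cnc3c(Cl)ncnc32)cc1` gives 3010 nM in this assay, a gap beyond the usual scatter. Compound 3 `ClCc1ccccc1Cn1cnc2c(Cl)ncnc21` differs from compound 2 by hydrogen in place of chloro on an aromatic carbon. Among the compounds with values here, no measured pair shows this change by itself. For compound 3 the expected step is a 2.0-fold higher number from compound 2 to compound 3 (0.29 log units; within the scatter), a modest move toward a weaker number, since compound 3 carries the single-chloro core of compound 1, whose number is 3010 nM. Compound 3 is therefore estimated at 2000 nM, within 800 nM to 5000 nM.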

Compound 3, concentration for total growth inhibition: 6160 nM
Compound 3: the middle estimate sits 3.1-fold (0.49 log units) below what was measured; measured number outside the range, above it.
By their numbers in this assay, from the lowest: compound 2; then compound 1; then compound 3.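

In this assay replacing the chloro with hydrogen gives a 6.0-fold higher number from compound 2 to compound 3 (0.78 log units; beyond the scatter) and so puts a first direct size on this change. Within the data shown here, the chloro on this aromatic carbon, between two ring nitrogen atoms, goes with the lower number, a link that the earlier compounds, which differ in more than one place, could not isolate. Nothing measured here accounts for the step.

Going by these compounds, whether an amine or a methoxy group on this carbon would retain the number of compound 2 remains open. So does whether the step would recur with the chloromethyl group placed as in compound 1.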